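Exchanging the Oxy Link for an Amino Link

This account rests on a few compounds, and the source may have more. Where it says the series, first, only, none or still open, it means among the compounds named here.

In a functional assay on PC-3 cells (Homo sapiens) for antiproliferative activity, read by sulforhodamine B assay, with a stated time of 48 h (a higher number here means a weaker inhibitor, a lower number a stronger inhibitor), compound 1 (`C/C=C(\C)C(=O)O[C@H]1C=CC(=O)O[C@H]1CCC(=O)[C@H](C)O`) gives 23000 nM and compound 2 (`C/C=C(\C)C(=O)O[C@H]1C=CC(=O)O[C@H]1COC(=O)[C@H](C)O`) gives 16000 nM, so compound 2 stands within the scatter of compound 1. Compound 3 (`C/C=C(\C)C(=O)O[C@H]1C=CC(=O)O[C@H]1CNC(=O)[C@H](C)O`) carries ((1-hydroxyethyl)carbonyl)amino in place of ((1-hydroxyethyl)carbonyl)oxy on a saturated chain carbon bound to a saturated ring carbon. Within the data shown here, the only measured step, a 1.4-fold lower number from compound 1 to compound 2 (0.16 log units; within the scatter), exchanged a group at that same place and stayed within the scatter. No change beyond the scatter is therefore expected in this assay, and the expected step is a 1.3-fold higher number from compound 2 to compound 3 (0.10 log units; within the scatter). For compound 3 the estimate is 20000 nM, with a range of 10000 nM to 40000 nM.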

Compound 3, half-maximal inhibitory concentration: 25000 nM
Beside the measured number, compound 3's estimate is 1.3-fold (0.10 log units) below it; measured number inside the range.
By their numbers in this assay, from the lowest: compounds 2, 1 and 3 (each within the scatter of the next).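

In this assay, the amino link gives a 1.6-fold higher number from compound 2 to compound 3 (0.19 log units; within the scatter), and against the methylene-linked compound it gives a 1.1-fold higher number from compound 1 to compound 3 (0.04 log units; within the scatter). At this place on the saturated chain carbon, all three links therefore read alike, so exchanging the linking atom has so far produced no change beyond the scatter. No measurement at hand offers an explanation for this.

The compounds shown leave open whether a larger change at this place, such as a longer chain or a carboxylic acid in place of the 1-hydroxyethyl group, would separate from these numbers.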